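Compound 3: A Trifluoromethoxy Exchange Awaits Its Measurement

A few compounds are considered here, and "the series" means these few. Any claim that something is new, unique, unknown or untested is made for them only; others in the source may bear on it.

Of the compounds shown here, two have so far been measured in a functional assay on CWR22R cells (Homo sapiens) for antiproliferative activity, read by propidium iodide staining, with a stated time of 96 h; a lower number here means a stronger inhibitor, a higher number a weaker inhibitor. Compound 1 (`CC(O)(COc1ccc(S(F)(F)(F)(F)F)cc1)C(=O)Nc1ccc(S(F)(F)(F)(F)F)cc1`) gives 13000 nM, and compound 2 (`CC(O)(COc1cccc(S(F)(F)(F)(F)F)c1)C(=O)Nc1ccc(S(F)(F)(F)(F)F)cc1`) gives 17600 nM. Compound 1 holds the lowest of these two numbers, but the gap lies within the scatter, so the pair cannot be ranked. Both sit at a high level on this scale.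

The next compound is compound 3 (`CC(O)(COc1ccc(OC(F)(F)F)cc1)C(=O)Nc1ccc(S(F)(F)(F)(F)F)cc1`), not yet measured in this assay. It departs from compound 1 at one place: a group of 5 heavy atoms (1 carbon, 1 oxygen, 3 fluorine; no ring) in place of a group of 6 heavy atoms (5 fluorine, 1 sulfur; no ring), on an aromatic carbon. Trifluoromethoxy enters on an aromatic carbon, para to a large group, and replaces a group of 5 fluorine and 1 sulfur. The shared core stays the same.

Among the measured compounds shown here, no step between measured compounds shows what such an exchange does, so the expectation rests only on compound 1 at 13000 nM and on the closeness of compound 2 at 17600 nM. The expected change is none beyond the scatter, with an estimated 1.2-fold higher number from compound 1 to compound 3 (0.09 log units; within the scatter). Compound 3 is expected at 16000 nM, with an estimated range of 7000 nM to 35000 nM.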

Compound 3, half-maximal inhibitory concentration: 27900 nM
Estimate against measurement, compound 3: 1.7-fold (0.24 log units) below; measured number inside the range.
By their numbers in this assay, from the lowest: compounds 1, 2 and 3 (each within the scatter of the next, the first and the last beyond it).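

In this assay, among the compounds shown here, the exchange of the group of 5 fluorine and 1 sulfur for trifluoromethoxy, on an aromatic carbon para to a large group, gives the first step that can be read: a 2.1-fold higher number from compound 1 to compound 3 (0.33 log units; beyond the scatter), a modest step that lies beyond the scatter. The earlier pair could not be ranked, whereas this step shows that the number responds to what sits at this place, with the group in compound 1 going with the lower number of the two, although both compounds remain at a high level on this scale. No measurement at hand bears on why the number moves with this exchange.

The compounds shown leave open how other groups at this place, such as chlorine, a nitrile or an amine, would compare with the two tried here, and so whether any exchange here could bring the number down rather than up. They also leave open whether trifluoromethoxy would have a like effect in place of the second group of 5 fluorine and 1 sulfur, which stays unchanged in the shared core.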